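The source may report more compounds than this note shows. Statements on the series, on what has been measured and on what is new or still open speak of the compounds shown alone.

Two thiourea amides sharing one core were compared in a functional assay on MKN-74 cells (Homo sapiens) for antiproliferative activity, with a stated time of 24 h; on this read-out higher numbers stand for weaker inhibition and lower numbers for stronger inhibition. Compound 1 `NC(=O)c1c(NC(=O)c2ccccc2Br)sc2c1CCN(C(=S)Nc1ccccc1Cl)C2` gives 12900 nM, and compound 2 `NC(=O)c1c(NC(=O)c2ccccc2I)sc2c1CCN(C(=S)Nc1ccccc1Cl)C2` gives 17500 nM, the higher of the two numbers. Among the compounds with values here, the only measured step, a 1.4-fold higher number from compound 1 to compound 2 (0.13 log units; within the scatter), exchanges one halogen for another on the aromatic carbon and stays within the scatter, so the two compounds are not separated on this read-out. Compound 3 `CSc1ccccc1C(=O)Nc1sc2c(c1C(N)=O)CCN(C(=S)Nc1ccccc1Cl)C2` differs from compound 2 by methylsulfanyl in place of iodo on an aromatic carbon. Within the data shown here, no measured pair shows a halogen giving way to methylsulfanyl, so the halogen step is only a loose guide: it suggests that substituents of this kind at this aromatic carbon leave the number little changed. The step expected from compound 2 to compound 3 is therefore small, a 1.3-fold lower number from compound 2 to compound 3 (0.10 log units; within the scatter), with no direction asserted beyond the scatter. On that basis compound 3 is estimated at 14000 nM, within a range from 5000 nM to 40000 nM.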

Compound 3, half-maximal inhibitory concentration: 6550 nM
Beside the measured number, compound 3's estimate is 2.1-fold (0.33 log units) above it; the measured number falls inside the stated range.
By their numbers in this assay, from the lowest: compounds 3, 1 and 2 (each within the scatter of the next, the first and the last beyond it).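

At the aromatic carbon ortho to a large group, the halogen exchange had left the number within the scatter, but methylsulfanyl in place of iodo shows that a change here can move it beyond the scatter in this assay, with a 2.7-fold lower number from compound 2 to compound 3 (0.43 log units; beyond the scatter). Within the data shown here, measured against bromo, the same group gives a 2.0-fold lower number from compound 1 to compound 3 (0.29 log units; within the scatter), which stays within the scatter, so the separation rests on the single pair with iodo and is modest in size. No evidence is available to account for this difference between methylsulfanyl and the halogens.

The compounds shown leave open how a methoxy group, an amine, a carboxylic acid or a longer chain such as ethylsulfanyl would read at this carbon. They also leave open whether the step from iodo to methylsulfanyl would hold with a different group on the thiourea.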